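The source may report more compounds than this note shows. Statements on the series, on what has been measured and on what is new or still open speak of the compounds shown alone.

Measured in a functional assay on the whole organism with Rattus norvegicus as the target; a higher number here means that more compound is needed for the effect, a lower number that less compound is needed:
- compound 1 `CCOC(=O)C(=O)Nc1nc(-c2cccc(O)c2)cs1`: > 10 mg/kg (a limit)
- compound 2 `CCOC(=O)C(=O)Nc1nc(-c2ccc(O)cc2)cs1`: about 15 mg/kg
- compound 3 `O=C(O)C(=O)Nc1nc(-c2ccc(O)cc2)cs1`: > 3 mg/kg (a limit)

Within the data shown here, compound 2 holds the only actual number, as the other two values are limits. Its position relative to compound 1 and compound 3 therefore cannot be read.

The next compound is compound 4 `CCOC(=O)C(=O)Nc1ccc(-c2csc(NC(=O)C(=O)OCC)n2)cc1`, still to be measured. Its change from compound 2 is ((ethoxycarbonyl)carbonyl)amino in place of hydroxy on an aromatic carbon, para to a large group.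

Among the measured compounds shown here, the only measured step is a step that the limit leaves unreadable from compound 2 to compound 3. It concerns the ethyl group rather than the hydroxy, and it gives no size to carry over. For the measured compounds named here, no measured step covers the exchange of the hydroxy, so no direction can be drawn from the data, and no step beyond the scatter is expected in this assay. The expectation therefore stays with compound 2 at about 15 mg/kg.

The expected step is no change at the digits printed from compound 2 to compound 4 (within the scatter).

For compound 4 the estimated value is 15 mg/kg, with an expected range of 5 mg/kg to 45 mg/kg.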

Compound 4, dose for half-maximal effect: > 30 mg/kg
Compound 4 ended at the assay's limit; the forecaster's own chance of this, stated with the estimate: 40%; middle value at least 2.0-fold (0.30 log units) away from the limit.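

In this assay, among these compounds, the exchange of hydroxy for ((ethoxycarbonyl)carbonyl)amino on an aromatic carbon, para to a large group, gives the first readable step: an at least 2.0-fold higher number from compound 2 to compound 4 (0.30 log units; that floor lies within the scatter). Compound 4 gives > 30 mg/kg, and this value is a limit of the assay. The exchange therefore shows no lower number at this position, while the true size of the step remains unread and its floor lies within the scatter.

From the compounds shown here alone, it remains open whether an amine or a methoxy group at this position would stay with the number of compound 2 or move away from it. The other steps among these compounds cannot be read, so the exchange of ethyl for hydrogen also remains without a size.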